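The source may report more compounds than this note shows. Statements on the series, on what has been measured and on what is new or still open speak of the compounds shown alone.

Three amides that share one core have been tested in a functional assay on MCF7 cells (Homo sapiens) for antiproliferative activity, read by MTT assay, with a stated time of 72 h; a higher number here means a weaker inhibitor, a lower number a stronger inhibitor. There, compound 1 `CCN1CCN(c2cc(C)c3cc(NC(=O)c4ccc(F)cc4)ccc3n2)CC1` gives 4030 nM, compound 2 `CCN1CCN(c2cc(C)c3cc(NC(=O)c4ccc(Br)cc4)ccc3n2)CC1` gives 5940 nM, and compound 3 `CCN1CCN(c2cc(C)c3cc(NC(=O)c4ccccc4F)ccc3n2)CC1` gives 32600 nM. Compound 3 has the highest number of the three, which makes it the weakest inhibitor of this small set, and its steps to both others are beyond the scatter.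

Compound 4 `CCN1CCN(c2cc(C)c3cc(NC(=O)c4ccccc4Cl)ccc3n2)CC1` differs from compound 3 by a single substitution: chloro in place of fluoro on an aromatic carbon. This places chloro in place of fluoro on an aromatic carbon, ortho to a large group. The closest measured comparison is another halogen swap, bromo in place of fluoro, and a 1.5-fold higher number from compound 1 to compound 2 (0.17 log units; within the scatter). For the measured compounds named here, that is only one example, and it involves the 4-substituted phenyl group rather than the 2-substituted one. The larger steps, an 8.1-fold higher number from compound 1 to compound 3 (0.91 log units; beyond the scatter) and a 5.5-fold higher number from compound 2 to compound 3 (0.74 log units; beyond the scatter), both move the halogen, which does not happen here. The expected outcome is therefore no step beyond the scatter, with an estimated 1.1-fold lower number from compound 3 to compound 4 (0.04 log units; within the scatter). In this assay the estimate for compound 4 is 30000 nM, with an expected range of 12000 nM to 70000 nM.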

Compound 4, half-maximal inhibitory concentration: > 50000 nM
Compound 4: no number, only a limit; the forecaster's own chance of this, stated with the estimate: 10%; at least 1.6-fold (0.22 log units) between middle value and limit.
By their numbers in this assay, from the lowest: compounds 1 and 2 (each within the scatter of the next); then compound 3. At a limit, above all of these: compound 4.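

Compound 4 has no number in this assay, only a limit: the limit of > 50000 nM in this assay, at which 1 of the 4 values shown sits. On these data alone, the change from 2-fluorophenyl to 2-chlorophenyl gives an at least 1.5-fold higher number from compound 3 to compound 4 (0.18 log units; that floor lies within the scatter), so this floor does not separate the two compounds, and the true size of the step remains unknown. The new compound does show that the high number of compound 3 is not confined to a fluoro group, since the 2-chlorophenyl amide also stands well clear of the two 4-substituted amides, with an at least 8.4-fold higher number from compound 2 to compound 4 (0.92 log units; beyond the scatter) and an at least 12-fold higher number from compound 1 to compound 4 (1.09 log units; beyond the scatter).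

As far as these compounds go, whether compound 4 lies close to compound 3 or far beyond it stays open. Also open, from the compounds shown here alone, is how a methyl or methoxy group would read in place of the halogen on the 2-substituted phenyl group.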